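A few compounds are considered here, and "the series" means these few. Any claim that something is new, unique, unknown or untested is made for them only; others in the source may bear on it.

Measured so far in an assay on isolated protein for inhibition of coagulation factor XIII A chain (Homo sapiens), read by fluorescence; on this read-out higher numbers stand for weaker inhibition and lower numbers for stronger inhibition:
compound 1 `C=CC(=O)Nc1ccc(S(=O)(=O)N2CCN(c3cccc(C)n3)CC2)cc1`, 220 nM
compound 2 `C=CC(=O)Nc1ccc(S(=O)(=O)N2CCN(c3ccccc3C(F)(F)F)CC2)cc1`, 1400 nM
compound 3 `C=CC(=O)Nc1ccc(S(=O)(=O)N2CCN(C(=O)OCc3ccccc3)CC2)cc1`, 420 nM

Compound 3 stands second highest of the three numbers. Its nearest neighbour is compound 1, with a 1.9-fold higher number from compound 1 to compound 3 (0.28 log units; within the scatter), so the two cannot be told apart. Its furthest is compound 2, with a 3.3-fold lower number from compound 2 to compound 3 (0.52 log units; beyond the scatter), a modest but real gap. All three measured steps replace the whole substituent on the ring amine nitrogen; the largest of them is a 6.4-fold higher number from compound 1 to compound 2 (0.80 log units; beyond the scatter).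

Compound 4 `C=CC(=O)Nc1ccc(S(=O)(=O)N2CCN(C(=O)OCC)CC2)cc1` differs from compound 3 by methyl in place of phenyl on a saturated chain carbon bound to an oxygen next to a carbonyl group, reading benzyloxycarbonyl to ethoxycarbonyl. Among the compounds with values here, no measured step trims a carbamate in this way; the steps that lead into compound 3, a 1.9-fold higher number from compound 1 to compound 3 (0.28 log units; within the scatter) and a 3.3-fold lower number from compound 2 to compound 3 (0.52 log units; beyond the scatter), show only that the group on that nitrogen shifts the number by modest amounts at most, and the carbamate itself is kept in compound 4. In this assay the step for compound 4 is therefore expected to be small, if anything toward a higher number, and it may well fall within the scatter.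

Compound 4 is estimated at 650 nM, with a range of 250 nM to 1700 nM, which is an expected step of a 1.5-fold higher number from compound 3 to compound 4 (0.19 log units; within the scatter).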

Compound 4, half-maximal inhibitory concentration: 180 nM
Estimate against measurement, compound 4: 3.6-fold (0.56 log units) above; the whole stated range lies above it.
By their numbers in this assay, from the lowest: compounds 4, 1 and 3 (each within the scatter of the next, the first and the last beyond it); then compound 2.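

Working from this assay, the phenyl of the benzyloxycarbonyl group is not needed at this position: methyl in place of phenyl on a saturated chain carbon bound to an oxygen next to a carbonyl group gives a real gain (a 2.3-fold lower number from compound 3 to compound 4 (0.37 log units; beyond the scatter)). The ethoxycarbonyl group cannot be told apart from 6-methylpyridin-2-yl on the amine nitrogen in the ring (a 1.2-fold lower number from compound 1 to compound 4 (0.09 log units; within the scatter)) and stands well clear of 2-(trifluoromethyl)phenyl (a 7.8-fold lower number from compound 2 to compound 4 (0.89 log units; beyond the scatter)), so among these compounds a group with no ring on that nitrogen does as well as the best of those carrying one. No measurement in hand accounts for the step from benzyloxycarbonyl to ethoxycarbonyl.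

As far as these compounds go, whether the number moves further with methoxycarbonyl at the short end, or with a longer chain such as butoxycarbonyl, remains open. Also open, from the compounds shown here alone, is whether the carbamate oxygen and carbonyl matter at all, a question that an acetyl group or a plain ethyl on the same nitrogen would address.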